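Replacing the Aryl Group on a Shared Kinase Inhibitor Core

This account rests on a few compounds, and the source may have more. Where it says the series, first, only, none or still open, it means among the compounds named here.

Compound 1, `CN1C(=O)C(c2cccc(Cl)c2)N(C)c2nc(Nc3ccc(S(N)(=O)=O)cc3)ncc21`: 989 nM
Compound 2, `CN1C(=O)C(c2cccc(C(F)(F)F)c2)N(C)c2nc(Nc3ccc(S(N)(=O)=O)cc3)ncc21`: 2710 nM
Compound 3, `CN1C(=O)C(c2c(F)cccc2F)N(C)c2nc(Nc3ccc(S(N)(=O)=O)cc3)ncc21`: 42 nM

In an assay on Sf9 cells for inhibition of serine/threonine-protein kinase 4 (Homo sapiens), read by luminescence and ADP-Glo, with a stated time of 1 h, in the presence of a further agent that is not named here (on this read-out higher numbers stand for weaker inhibition and lower numbers for stronger inhibition), compound 1 stands second highest of the three numbers. Its nearest neighbour is a modest step, a 2.7-fold higher number from compound 1 to compound 2 (0.44 log units; beyond the scatter); its furthest is a large one, a 24-fold lower number from compound 1 to compound 3 (1.37 log units; beyond the scatter).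

Compound 4, `CN1C(=O)C(c2cccs2)N(C)c2nc(Nc3ccc(S(N)(=O)=O)cc3)ncc21`, is not yet measured. thiophen-2-yl in place of 3-chlorophenyl on a saturated ring carbon The two large steps, a 24-fold lower number from compound 1 to compound 3 (1.37 log units; beyond the scatter) and a 65-fold lower number from compound 2 to compound 3 (1.81 log units; beyond the scatter), also change the group on this saturated ring carbon, but both bring in 2,6-difluorophenyl. Among the compounds with values here, no measured step swaps the six-membered aromatic ring for a five-membered one, so the direction of any step beyond the scatter is uncertain. Compound 4 is expected to give about 1200 nM, within 300 nM to 5000 nM, an estimated step of a 1.2-fold higher number from compound 1 to compound 4 (0.08 log units; within the scatter).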

Compound 4, half-maximal inhibitory concentration: 88 nM
Compound 4: middle estimate off by 14-fold (1.13 log units), on the high side; the measured number lies below the stated range.
By their numbers in this assay, from the lowest: compound 3; then compound 4; then compound 1; then compound 2.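

In this assay thiophen-2-yl on this saturated ring carbon gives an 11-fold lower number from compound 1 to compound 4 (1.05 log units; beyond the scatter) and a 31-fold lower number from compound 2 to compound 4 (1.49 log units; beyond the scatter) against the substituted phenyl groups, so a large gain here does not depend on 2,6-difluorophenyl or on a six-membered aromatic ring. Compound 3 still keeps a modest edge, as a 2.1-fold higher number from compound 3 to compound 4 (0.32 log units; beyond the scatter) shows. Nothing measured on these compounds accounts for the steps. On these data alone, it remains open whether unsubstituted phenyl, furan-2-yl or a saturated cyclohexyl group would give lower or higher numbers at this carbon.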